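Swapping the Group Beside the Amide Carbonyl

This account rests on a few compounds, and the source may have more. Where it says the series, first, only, none or still open, it means among the compounds named here.

Compound 1 `Cn1c(-c2ccc(NC(=O)CCl)cc2)nc(-c2ccccc2)c1-c1ccccc1`: 4.3%
Compound 2 `Cn1c(-c2ccc(NC(=O)CSc3nc4ccccc4s3)cc2)nc(-c2ccccc2)c1-c1ccccc1`: 2.1%
Compound 3 `Cn1ccnc1SCC(=O)Nc1ccc(-c2nc(-c3ccccc3)c(-c3ccccc3)n2C)cc1`: 17.5%

All three were tested in a functional assay on MCF7 cells (Homo sapiens) for cytotoxicity, read by MTT assay, with a stated time of 24 h, tested at 1.6 ug/mL; a higher number here means a stronger effect of the compound at the concentration tested, a lower number a weaker effect. Compound 2 gives the lowest of the three numbers; compound 1 sits closest to it, and the gap a number 2.2 percentage points lower from compound 1 to compound 2 (within the scatter) lies within the scatter, so these two cannot be ranked. Compound 3 lies furthest away, with a number 15.4 percentage points higher from compound 2 to compound 3 (beyond the scatter), a modest rise that goes beyond the scatter.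

Compound 4 `Cn1c(-c2ccc(NC(=O)CN3CCN(c4ccccc4)CC3)cc2)nc(-c2ccccc2)c1-c1ccccc1` differs from compound 2 in one place: 4-phenylpiperazin-1-yl in place of (1,3-benzothiazol-2-yl)sulfanyl on a saturated chain carbon bound to a carbonyl carbon. Within the data shown here, none of the measured steps tried this particular group, so they guide only loosely. The step of a number 2.2 percentage points lower from compound 1 to compound 2 (within the scatter) shows that a small chloro and a larger (1,3-benzothiazol-2-yl)sulfanyl give much the same weak effect, while a number 13.2 percentage points higher from compound 1 to compound 3 (beyond the scatter) and a number 15.4 percentage points higher from compound 2 to compound 3 (beyond the scatter) show that one other replacement at this position raised the number modestly.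

Compound 4 is therefore expected to stay in the weak range, with the step of a number 5.9 percentage points higher from compound 2 to compound 4 (within the scatter) likely within the scatter. The estimate for compound 4 in this assay is 8%, with a range from 0% to 25%.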

Compound 4, a percentage reported as activity, at one concentration (the size of the read-out at that concentration, not a potency): 21.3%
Compound 4: middle estimate off by 13.3 percentage points, on the low side; low and high end bracket the measured number.
By their numbers in this assay, from the lowest: compounds 2 and 1 (each within the scatter of the next); then compounds 3 and 4 (each within the scatter of the next).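

At this saturated chain carbon bound to a carbonyl carbon, a group attached through nitrogen can also raise the number in this assay: 4-phenylpiperazin-1-yl gives a number 19.2 percentage points higher from compound 2 to compound 4 (beyond the scatter) and a number 17 percentage points higher from compound 1 to compound 4 (beyond the scatter), both modest rises. The rise seen with (1-methyl-1H-imidazol-2-yl)sulfanyl is therefore no longer a single case, and the step of a number 3.8 percentage points higher from compound 3 to compound 4 (within the scatter) leaves these two replacements unranked. The 4-phenylpiperazin-1-yl group and the (1,3-benzothiazol-2-yl)sulfanyl group are close in size, so heavy-atom count alone does not account for this step.

Nothing available here explains why these groups give different numbers. On these data alone, it also remains open whether the phenyl ring of 4-phenylpiperazin-1-yl matters, a question that a plain piperazine or a dimethylamino group at this place would address.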